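A few compounds are considered here, and "the series" means these few. Any claim that something is new, unique, unknown or untested is made for them only; others in the source may bear on it.

Measured in a functional assay on PC-3 cells (Homo sapiens) for antiproliferative activity, read by sulforhodamine B assay, with a stated time of 48 h; a lower number here means a stronger inhibitor of growth, a higher number a weaker inhibitor of growth:
compound 1 `CC(C)CCc1c(OCCCCCCC(=O)NO)ccc2c1OC(=O)CC2`: > 30000 nM
compound 2 `CC(C)CCc1c(OCCCCC(=O)NO)ccc2ccc(=O)oc12`: 1940 nM
compound 3 `CC(C)CCc1c(OCCCCC(=O)NO)ccc(CCC(=O)NO)c1O`: 14400 nM

Compound 1 gives only a limit in this assay, > 30000 nM, not a number. Compound 4 `CC(C)CCc1c(OCCCCC(=O)NO)ccc2c1OC(=O)CC2` differs from it in one place: hydroxycarbamoyl in place of 2-(hydroxycarbamoyl)ethyl on a saturated chain carbon, four bonds along the chain from an oxygen on an aromatic ring. Going by the values given here, no measured pair isolates this change. The shorter chain of compound 4 also occurs in compound 2, at 1940 nM, and in compound 3, at 14400 nM. Both of these give numbers, but their cores differ from that of compound 1, so they are only a loose guide. A clear gain in growth inhibition is therefore expected, with an estimated step of an at least 3.7-fold lower number from compound 1 to compound 4 (0.57 log units; beyond the scatter). For compound 4 the estimated value is 8000 nM, with an expected range from 2000 nM to 30000 nM.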

Compound 4, concentration for 50% growth inhibition: > 30000 nM
Compound 4 was reported as a limit; the forecaster's own chance of this, stated with the estimate: 25%; middle value at least 3.7-fold (0.57 log units) away from the limit.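

No step can be read between compound 1 and compound 4, because each gives only a limit in this assay: the limit of > 30000 nM in this assay, at which 2 of the 4 values shown sit.

The compounds shown leave open whether this change in chain length alters growth inhibition on the core of compound 1 at all.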